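Two amide variants, level; a third combines their features

The source may report more compounds than this note shows. Statements on the series, on what has been measured and on what is new or still open speak of the compounds shown alone.

Measured compounds:
compound 1 `COC(=O)C1=C(C)NC(C)=C(C(=O)OC)C1c1ccc(OCC(=O)N2CCCC(C)C2)c(OC)c1` — 10000 nM
compound 2 `COC(=O)C1=C(C)NC(C)=C(C(=O)OC)C1c1cccc(OCC(=O)N2CCN(C)CC2)c1` — 10000 nM

In an assay on cells for inhibition of Voltage-gated L-type calcium channel (Rattus norvegicus), read by fluorescence and calcium flux, with stated times of 30 min and 2 min (on this read-out higher numbers stand for weaker inhibition and lower numbers for stronger inhibition), compound 1 gives 10000 nM. Compound 2 gives 10000 nM in this assay, so compound 1 stands level with compound 2 at the digits shown; the two values lie within the scatter of each other, and no order between them can be read. Within the data shown here, compound 1 and compound 2 differ in more than one place on the shared core, so no single step between them is traced here; their values simply show the same number.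

Compound 3 `COC(=O)C1=C(C)NC(C)=C(C(=O)OC)C1c1ccc(OCC(=O)N2CCN(C)CC2)c(OC)c1` has not yet been measured. It differs from compound 1 by 4-methylpiperazin-1-yl in place of 3-methylpiperidin-1-yl on a carbonyl carbon. Among the measured compounds shown here, the same group that enters here is the one carried by compound 2, which sits at the same value as compound 1. On that basis no step beyond the scatter is expected from compound 1 to compound 3, and no change at the digits printed from compound 1 to compound 3 (within the scatter) is the estimated step. For compound 3 the expected value in this assay is 10000 nM, with a range from 4000 nM to 25000 nM.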

Compound 3, half-maximal inhibitory concentration: 9100 nM
Compound 3: middle estimate off by 1.1-fold (0.04 log units), on the high side; low and high end bracket the measured number.
By their numbers in this assay, from the lowest: compounds 3, 1 and 2 (each within the scatter of the next).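

Among these compounds, this is the first comparison that changes one place only: the rest of compound 1 stays fixed while the group on a carbonyl carbon whose other neighbour is a saturated chain carbon changes. In this assay, placing 4-methylpiperazin-1-yl there instead of 3-methylpiperidin-1-yl gives a 1.1-fold lower number from compound 1 to compound 3 (0.04 log units; within the scatter). The two groups have the same count of heavy atoms but differ in ring composition, with five carbons and two nitrogens in the entering group against six carbons and one nitrogen in the leaving one, and this exchange leaves no difference that can be read at this position.

Among the compounds shown here, the single step covers only these two six-membered amine groups, so it cannot show whether this position would respond to a morpholine ring, a dimethylamino group or a longer chain carrying a terminal carboxylic acid. Nor does it show whether the same exchange would read alike on a different core, as one step on the core of compound 1 cannot speak for any other.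

No measurement given here explains why these two amides read alike.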